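The source may report more compounds than this note shows. Statements on the series, on what has been measured and on what is new or still open speak of the compounds shown alone.

Measured so far in an ADME assay on microsomes from liver (Rattus norvegicus, strain Wistar) for metabolic stability, tested at 2.5 uM; on this read-out higher numbers stand for fast clearance and lower numbers for slow clearance:
- compound 1 `Brc1cccc2c1nnn2CC1CC1`: 0.6 mL/min/g
- compound 2 `CCCn1nnc2c(Br)cccc21`: 0.8 mL/min/g
- compound 3 `Cn1nnc2c(Br)cccc21`: "not determined" (no result reported)

Compound 1 has the lowest of the two numbers reported in this assay. For the measured compounds named here, its nearest neighbour is compound 2, and the single comparison available between compounds that differ in one place is a 1.3-fold higher number from compound 1 to compound 2 (0.12 log units; within the scatter). Compound 3 has no result in this assay, so it adds nothing to the picture.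

Compound 4 `FC(F)(F)c1cc(Br)c2nnn(CC3CC3)c2c1` has not yet been measured in this assay. It differs from compound 1 by trifluoromethyl in place of hydrogen on an aromatic carbon. Going by the values given here, the change sits on the six-membered aromatic ring of carbon only, meta to the bromo group, while the one measured step concerns the saturated chain carbon bound to an aromatic nitrogen, so no measured step speaks directly to this change. Among the compounds with values here, the only guidance is that the one step seen so far stayed within the scatter.

With nothing pointing either way, compound 4 is expected to give a number close to that of compound 1, with no change at the digits printed from compound 1 to compound 4 (within the scatter) a step that stays within the scatter. The estimate for compound 4 in this assay is 0.6 mL/min/g, with a range from 0.3 mL/min/g to 1.2 mL/min/g.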

Compound 4, intrinsic clearance in a liver preparation (reported as CLH), per the amount of preparation that the assay uses: 0.2 mL/min/g
Beside the measured number, compound 4's estimate is 3.0-fold (0.48 log units) above it; the measured number lies below the stated range.
By their numbers in this assay, from the lowest: compound 4; then compounds 1 and 2 (each within the scatter of the next).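

The earlier step in this assay concerned the chain on the aromatic nitrogen and stayed within the scatter, so it gave no sign that any change to the shared core could shift the number. Trifluoromethyl in place of hydrogen on an aromatic carbon, meta to the bromo group, gives a 3.0-fold lower number from compound 1 to compound 4 (0.48 log units; beyond the scatter), a modest step but the only one here beyond the scatter, and it runs towards slower clearance. This position on the six-membered ring of carbon is therefore one where a change can move the read-out, though the explanation for this shift remains unknown, as no measurement of any underlying property accompanies the result.

A single group at a single position cannot show whether this step is particular to trifluoromethyl, and a chloro group, a methoxy group, a nitrile or an amine on the same carbon would help to settle that. Going by these compounds, it also remains open whether the same change on compound 2, which carries a different chain, would give a step of similar size.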